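A few compounds are considered here, and "the series" means these few. Any claim that something is new, unique, unknown or untested is made for them only; others in the source may bear on it.

Compound 1 `CCCn1c(-c2ccc(O)cc2)c(C)c2cc(O)ccc21`: 2900 nM
Compound 2 `Cc1ncsc1C(=O)Oc1ccc(-c2[nH]c3ccccc3c2C)cc1`: > 20000 nM

Among the compounds with values here, in a functional assay on MSTO-211H cells (Homo sapiens) for inhibition, read by trypan blue exclusion, with a stated time of 72 h (a lower number here means a stronger inhibitor of growth, a higher number a weaker inhibitor of growth), compound 1 gives 2900 nM, the only true number among the measured compounds. The reading for compound 2, > 20000 nM, is a limit of the assay and not a number. Compound 3 `Cc1c(-c2ccc(O)cc2)n(CCCCOc2ccccc2)c2ccc(O)cc12` has not yet been measured. It differs from compound 1 by phenoxymethyl in place of hydrogen on a saturated chain carbon, three bonds along the chain from an aromatic nitrogen. Within the data shown here, no measured step between related compounds shows what such a change does, so no shift beyond the usual scatter is assumed. The expected step is small, a 1.5-fold lower number from compound 1 to compound 3 (0.16 log units; within the scatter). For compound 3 the estimated value is 2000 nM, with an expected range from 500 nM to 9000 nM.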

Compound 3, concentration for 50% growth inhibition: 2900 nM
The estimate for compound 3 lay 1.5-fold (0.16 log units) below the measured number; measured number inside the range.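

In this assay, placing phenoxymethyl in place of hydrogen on a saturated chain carbon, three bonds along the chain from an aromatic nitrogen, gives no change at the digits printed from compound 1 to compound 3 (within the scatter). The earlier compounds shown here offered no step at this position; this one shows that the chain can carry a six-membered aromatic ring of carbon only and still give a true number. The reading for compound 2 remains a limit of the assay and not a number: the limit of > 20000 nM in this assay, at which 1 of the 3 values shown sits.

Going by these compounds, a single step cannot separate the contribution of the added chain carbon from that of the phenoxy ring, so it stays open whether a plain longer chain, an amine or a carboxylic acid in place of the phenoxymethyl would read the same. The compounds shown also leave open whether a fluorine on the phenoxy ring would shift the number.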